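The source may hold more compounds than are shown below. What is called first, only, known or untested is meant among the compounds shown, and "the series" means these compounds.

Of the compounds shown here, three sharing one core have been measured in a functional assay with Homo sapiens as the target; on this read-out higher numbers stand for weaker inhibition and lower numbers for stronger inhibition. Compound 1 `CC(C)[C@H](NC(=O)COc1cccc2ccccc12)C(=O)N[C@@H](CC(=O)O)C(=O)COc1ccc(C#N)cc1` gives 26700 nM in this assay, the highest of the three numbers. Compound 2 `CC(C)[C@H](NC(=O)COc1cccc2ccccc12)C(=O)N[C@@H](CC(=O)O)C(=O)COc1ccc(Oc2ccc(C(F)(F)F)cc2)cc1` gives 24900 nM, and compound 3 `CC(C)[C@H](NC(=O)COc1cccc2ccccc12)C(=O)N[C@@H](CC(=O)O)C(=O)COc1cc(F)ccc1F` gives 19700 nM. Neither stands apart from compound 1: the step of a 1.1-fold lower number from compound 1 to compound 2 (0.03 log units; within the scatter) and the step of a 1.4-fold lower number from compound 1 to compound 3 (0.13 log units; within the scatter) both lie within the usual scatter of repeated measurements, so the three compounds cannot be told apart on this read-out.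

Compound 4 `CC(C)[C@H](NC(=O)COc1cccc2ccccc12)C(=O)N[C@@H](CC(=O)O)C(=O)COc1ccc(F)c(F)c1F` has not yet been measured. It differs from compound 1 in one place: 2,3,4-trifluorophenyl in place of 4-cyanophenyl on an oxygen on a saturated carbon The closest measured comparison is the step of a 1.4-fold lower number from compound 1 to compound 3 (0.13 log units; within the scatter), where 2,5-difluorophenyl replaced the 4-cyanophenyl on an oxygen on a saturated carbon, and that step stayed within the scatter. The step of a 1.1-fold lower number from compound 1 to compound 2 (0.03 log units; within the scatter), which alters the 4-cyanophenyl in another way, was also within the scatter. On this evidence the change to compound 4 is expected to produce no step beyond the scatter, so compound 4 is estimated at 21000 nM with a range from 9000 nM to 50000 nM. That estimate corresponds to an expected step of a 1.3-fold lower number from compound 1 to compound 4 (0.10 log units; within the scatter).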

Compound 4, half-maximal inhibitory concentration: 20600 nM
Compound 4: the middle estimate sits 1.0-fold (0.01 log units) above what was measured, within the range that was stated.
By their numbers in this assay, from the lowest: compounds 3, 4, 2 and 1 (each within the scatter of the next).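

In this assay, the nitrile-bearing ring on this oxygen can be exchanged for a ring carrying three fluorines with a 1.3-fold lower number from compound 1 to compound 4 (0.11 log units; within the scatter), so this fluorine-only ring is no more separable from the 4-cyanophenyl group than the 2,5-difluorophenyl group was. Among the compounds shown here, the new comparison between two fluorinated rings, a 1.0-fold higher number from compound 3 to compound 4 (0.02 log units; within the scatter), adds that going from the 2,5-difluorophenyl group to the 2,3,4-trifluorophenyl group also leaves the read-out within the scatter, and every step printed for this position so far stays within it. No available data speak to what lies behind this flat picture.

The compounds shown leave open whether any group on this oxygen can produce a step beyond the scatter, for instance a ring carrying an amine or a carboxylic acid, or a plain saturated chain in place of the ring. All four compounds also share the same core, so they cannot show whether a change elsewhere in it would shift the read-out more than these ring exchanges do.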